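Piperidine substitution on the benzothiazole ether series

The source may hold more compounds than are shown below. What is called first, only, known or untested is meant among the compounds shown, and "the series" means these compounds.

Compound 1 `c1ccc2sc(Oc3ccc4c(CN5CCCCC5)coc4c3)nc2c1` is tested in an in vitro assay on Sf9 cells for inhibition of leukotriene A-4 hydrolase (Homo sapiens), read by immunoassay, with stated times of 10 min and 30 min (a higher number here means a weaker inhibitor, a lower number a stronger inhibitor), where compound 1 gives 67 nM. This is the highest of the three numbers recorded. Compound 2 `c1cnc2nc(Oc3ccc4oc(CN5CCCCC5)cc4c3)sc2c1`, measured at 66 nM, sits within the scatter of compound 1. Compound 3 `O=C(O)C1CCN(Cc2coc3cc(Oc4nc5ncccc5s4)ccc23)CC1`, which carries a carboxylic acid on the saturated ring, gives 8.3 nM, a number well beyond the scatter below compound 1. Compound 4 `O=C1CCCN1C1CCN(Cc2coc3cc(Oc4nc5ccccc5s4)ccc23)CC1` is not yet measured. It differs from compound 1 by 2-oxopyrrolidin-1-yl in place of hydrogen on a saturated ring carbon. Among the measured compounds shown here, no directly comparable step is recorded. A move toward a lower number is expected, a 3.7-fold lower number from compound 1 to compound 4 (0.57 log units; beyond the scatter), since compound 3 shows that a group on the saturated ring can go with a lower number, 8.3 nM. For compound 4 the estimate is 18 nM, with a range from 5 nM to 60 nM.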

Compound 4, half-maximal inhibitory concentration: 58 nM
Beside the measured number, compound 4's estimate is 3.2-fold (0.51 log units) below it; measured number inside the range.
By their numbers in this assay, from the lowest: compound 3; then compounds 4, 2 and 1 (each within the scatter of the next).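

In this assay, among the compounds shown here, the step with 2-oxopyrrolidin-1-yl in place of hydrogen on a saturated ring carbon is a 1.2-fold lower number from compound 1 to compound 4 (0.06 log units; within the scatter), the first single-place step. It shows that this ring carbon, three ring bonds from the ring nitrogen, can carry this group with no change in the number beyond the scatter. No data on hand bear on this result. Still open, on these data alone, is whether an amine or a hydroxyl on the same ring carbon would move the number beyond the scatter, and whether a carboxylic acid there on the core of compound 1 would do so.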